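A few compounds are considered here, and "the series" means these few. Any claim that something is new, unique, unknown or untested is made for them only; others in the source may bear on it.

Compound 1, `CC(C)=CC[C@H](OC(=O)C=C(C)C)C1=CC(=O)c2c(O)ccc(O)c2C1=O`: 4810 nM
Compound 2, `COc1ccc(O)c2c1C(=O)C=C(CCC=C(C)C)C2=O`: 8710 nM

Both were tested in a functional assay on DU-145 cells (Homo sapiens) for cytotoxicity, read by MTT assay, with a stated time of 48 h; a higher number here means a weaker inhibitor, a lower number a stronger inhibitor. Of the two numbers, compound 2 gives the higher one, yet its gap to compound 1 lies within the usual scatter, so the two cannot be told apart. Compound 3, `COc1ccc(O)c2c1C(=O)C=C([C@H](CC=C(C)C)OC(C)=O)C2=O`, has not yet been measured in this assay. Against compound 2 it differs in one place: acetoxy in place of hydrogen on a saturated chain carbon bound to a double-bonded ring carbon and a saturated chain carbon. Going by the values given here, no step between measured compounds is available to guide this change, so only a small step is expected, leaning toward a lower number, if any beyond the scatter. For compound 3 the estimate is 6000 nM, with a range from 2500 nM to 15000 nM, an expected step of a 1.5-fold lower number from compound 2 to compound 3 (0.16 log units; within the scatter).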

Compound 3, half-maximal inhibitory concentration: 7410 nM
Estimate against measurement, compound 3: 1.2-fold (0.09 log units) below; low and high end bracket the measured number.
By their numbers in this assay, from the lowest: compounds 1, 3 and 2 (each within the scatter of the next).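

In this assay the acetoxy group in place of hydrogen gives a 1.2-fold lower number from compound 2 to compound 3 (0.07 log units; within the scatter) and so adds four heavy atoms at this saturated chain carbon with no difference that can be told from the scatter. At this position, then, a group of this size leaves the measured cytotoxicity where compound 2 has it. Nothing available here accounts for this result. As far as these compounds go, whether an amine or a carboxylic acid on this same carbon would give a step beyond the scatter stays open. So does whether a longer ester chain there would.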